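Swapping 4-phenylphenyl for 2-(4-nitrophenyl)ethenyl: working notes

This account rests on a few compounds, and the source may have more. Where it says the series, first, only, none or still open, it means among the compounds named here.

Measured in a functional assay on NIH3T3 cells (Mus musculus) (a higher number here means that more compound is needed for the effect, a lower number that less compound is needed), so far:
Compound 1 `Cn1cncc1C(OCc1ccc(C#N)cc1-c1ccccc1)c1ccc(C#N)cc1` gives 140 nM
Compound 2 `Cn1cncc1C(OCc1ccc(C#N)cc1C#CC1(O)CCCCC1)c1ccc(C#N)cc1` gives 1.93 nM
Compound 3 `Cn1cncc1C(OCc1ccc(C#N)cc1-c1ccc(-c2ccccc2)cc1)c1ccc(C#N)cc1` gives < 0.1 nM (a limit of the assay, not a number)

Compound 3 stands at the limit of < 0.1 nM in this assay, at which 1 of the 3 values shown sits, and so remains a limit. Compound 4 `Cn1cncc1C(OCc1ccc(C#N)cc1/C=C/c1ccc([N+](=O)[O-])cc1)c1ccc(C#N)cc1` has not yet been measured and differs from compound 3 at one place 2-(4-nitrophenyl)ethenyl in place of 4-phenylphenyl on an aromatic carbon on the shared core.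

Among the compounds with values here, three measured steps bear on this change. Larger groups at this carbon came with lower numbers in the step of a 73-fold lower number from compound 1 to compound 2 (1.86 log units; beyond the scatter) and in the step of an at least 1400-fold lower number from compound 1 to compound 3 (3.14 log units; beyond the scatter) among these three compounds, and none of them goes against that. Exchanging one large group for another still gave an at least 19-fold lower number from compound 2 to compound 3 (1.28 log units; beyond the scatter) in favour of 4-phenylphenyl, so a swap of this kind may not pass unnoticed. Within the data shown here, no measured compound carries an ethenyl link or a nitro group, which leaves the size of the new step poorly fixed.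

A move of an at least 5.0-fold higher number from compound 3 to compound 4 (0.69 log units; beyond the scatter) is therefore expected in this assay as a rough estimate. For compound 4 the estimated value is 0.5 nM with an expected range from 0.1 nM to 5 nM for the coming measurement.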

Compound 4, half-maximal effective concentration: 2.24 nM
Compound 4: middle estimate off by 4.5-fold (0.65 log units), on the low side, within the range that was stated.
By their numbers in this assay, from the lowest: compounds 2 and 4 (each within the scatter of the next); then compound 1. At a limit, below all of these: compound 3.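

At this aromatic carbon, the heavy-atom count of the group does not settle the read-out in this assay: 4-phenylphenyl and 2-(4-nitrophenyl)ethenyl have similar counts, yet the exchange gives an at least 22-fold higher number from compound 3 to compound 4 (1.35 log units; beyond the scatter). That step is only a bound, since the value of compound 3 is a limit and not a number: the limit of < 0.1 nM in this assay, at which 1 of the 4 values shown sits. Two unlike groups, 2-(4-nitrophenyl)ethenyl and 2-(1-hydroxycyclohexyl)ethynyl, also turn out to be interchangeable at this carbon in this assay, with a 1.2-fold higher number from compound 2 to compound 4 (0.06 log units; within the scatter), while the phenyl group stays clearly apart, with a 63-fold lower number from compound 1 to compound 4 (1.80 log units; beyond the scatter).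

The compounds shown do not separate the ethenyl link from the nitro group, so it remains open which of the two goes with the distance from 4-phenylphenyl, and a plain 2-phenylethenyl or a 2-(4-aminophenyl)ethenyl group at this carbon would bear directly on that question. Also open, from the compounds shown here alone, is how far past its limit compound 3 lies, and whether a carboxylic acid or an amine on the terminal ring of 4-phenylphenyl would keep its standing in this assay.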